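The source may hold more compounds than are shown below. What is called first, only, known or untested is meant among the compounds shown, and "the series" means these compounds.

The series is followed in a functional assay on MDA-MB-231 cells (Homo sapiens) for inhibition; a higher number here means a weaker inhibitor of growth, a lower number a stronger inhibitor of growth. Compound 1 `Cc1ccc(N2CCN(CC(=O)Nc3ccc(-c4nc5ccccc5s4)cc3)CC2)cc1` gives 200 nM in this assay. Compound 2 `Clc1cccc(-n2cc(CNc3ccc(-c4nc5ccccc5s4)cc3)nn2)c1` gives 200 nM in this assay, level with compound 1 at the digits shown; these two numbers are together the lowest of the three measured. Compound 3 `Cc1cc(C)c2sc(NC(=O)c3ccc(C#N)cc3)nc2c1` gives 290 nM in this assay, a number that lies within the usual scatter of that of compound 1, so no order among the three compounds can be read from these figures.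

Compound 4 `O=C(CN1CCN(c2ccccc2)CC1)Nc1ccc(-c2nc3ccccc3s2)cc1` has not yet been measured in this assay. It differs from compound 1 in one place: hydrogen in place of methyl on an aromatic carbon. Going by the values given here, no step between two measured compounds that differ in a single place is available; the three measured compounds differ from one another in several places at once, so the size of this particular change has no measured counterpart.

The change keeps the shared core of compound 1 and removes one carbon from the outer ring. The expectation for this assay is a step from compound 1 to compound 4 of a 1.3-fold higher number from compound 1 to compound 4 (0.10 log units; within the scatter), that is, none beyond the scatter in either direction. Compound 4 is expected to give about 250 nM in this assay, within a range from 100 nM to 600 nM.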

Compound 4, concentration for 50% growth inhibition: 200 nM
Compound 4: the middle estimate sits 1.3-fold (0.10 log units) above what was measured; measured number inside the range.
By their numbers in this assay, from the lowest: compounds 1, 2, 4 and 3 (each within the scatter of the next).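

The series now has its first step between two measured compounds that differ in one place: in this assay, going from 4-methylphenyl to phenyl gives no change at the digits printed from compound 1 to compound 4 (within the scatter). Going by these compounds alone, at this position, para to a large group on a six-membered aromatic ring of carbon only, the step therefore gives no sign that the methyl matters for the growth-inhibition read-out, something the earlier compounds, which differ in several places at once, could not show. Nothing available bears on the reason for this result.

As far as these compounds go, the step covers only methyl and hydrogen, so it remains open whether other groups at the same place, such as a chlorine atom, methoxy, trifluoromethyl, a dimethylamino group or a carboxylic acid, would also stay within the scatter of compound 1. Also open, from the compounds shown here alone, is whether the same holds for a methyl group elsewhere on this ring, or for replacing the ring with a longer alkyl chain or a saturated ring such as cyclohexyl.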